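Benzoxazolone-carbamate series: nitro to methyl on the fused ring

A few compounds are considered here, and "the series" means these few. Any claim that something is new, unique, unknown or untested is made for them only; others in the source may bear on it.

Measured so far in an assay on HEK293 cells for inhibition of acid ceramidase (Homo sapiens), with a stated time of 10 min; a lower number here means a stronger inhibitor, a higher number a weaker inhibitor:
compound 1 `O=C(c1ccccc1)c1ccc2c(c1)oc(=O)n2C(=O)NCCCCc1ccccc1` — compound 1 gives 29 nM
compound 2 `O=C(NCCCCc1ccccc1)n1c(=O)oc2cc([N+](=O)[O-])ccc21` — compound 2 gives 3 nM

Going by the values given here, compound 2 stands lowest of the two numbers in this assay; the only neighbour is compound 1, with a 9.7-fold lower number from compound 1 to compound 2 (0.99 log units; beyond the scatter) separating them. Compound 3 `Cc1ccc2c(c1)oc(=O)n2C(=O)NCCCCc1ccccc1` is not yet measured and differs from compound 2 by methyl in place of nitro on an aromatic carbon. Among the compounds with values here, the single measured step bears on it only loosely, since that step exchanges nitro for benzoyl rather than for methyl. Both substituents that leave in the two changes carry acceptors, methyl carries none, so a higher number than compound 2 is expected in this assay, likely at or beyond the size of the measured step. Compound 3 is therefore estimated at 60 nM (range 15 nM to 250 nM), an expected 20-fold higher number from compound 2 to compound 3 (1.30 log units; beyond the scatter).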

Compound 3, half-maximal inhibitory concentration: 66 nM
Compound 3: the middle estimate sits 1.1-fold (0.04 log units) below what was measured; low and high end bracket the measured number.
By their numbers in this assay, from the lowest: compound 2; then compound 1; then compound 3.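

In this assay, methyl in place of nitro gives a 22-fold higher number from compound 2 to compound 3 (1.34 log units; beyond the scatter) at this aromatic carbon, so the number depends strongly on the group held there. Methyl in place of benzoyl gives a 2.3-fold higher number from compound 1 to compound 3 (0.36 log units; beyond the scatter) on the same carbon, which sets the three groups in a single order: nitro lowest, then benzoyl, then methyl. Where an amine, a methoxy group or a chlorine atom on this carbon would fall in that order remains open. Nothing measured here accounts for the order of these three groups.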